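A few compounds are considered here, and "the series" means these few. Any claim that something is new, unique, unknown or untested is made for them only; others in the source may bear on it.

Three compounds of one series share a core in which an aromatic amine carries a trifluoromethyl-substituted aryl group and a second substituent on the nitrogen. Compound 1, `COc1cc(N(CC2CC2)c2cccc(C(F)(F)F)c2)cnc1C(=O)[C@H]1C[C@@H]1C(=O)O`, bears a cyclopropylmethyl group there, and in an assay on isolated protein for inhibition of leukotriene C4 synthase (Homo sapiens), read by LC-MS, with stated times of 45 min and 20 min (a higher number here means a weaker inhibitor, a lower number a stronger inhibitor), compound 1 gives 52.4 nM. Among the compounds with values here, compound 2, `COc1cc(N(CC(C)(C)O)c2cccc(C(F)(F)F)c2)cnc1C(=O)[C@H]1C[C@@H]1C(=O)O`, carries the 2-hydroxy-2-methylpropyl group instead, but for compound 2 this assay returned "not determined" (no result reported), so no number places compound 2 on the scale; the only value to hand is the one for compound 1.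

Compound 3, `CCN(c1cccc(C(F)(F)F)c1)c1cnc(C(=O)[C@H]2C[C@@H]2C(=O)O)c(OC)c1`, is compound 2 with methyl in place of 1-hydroxy-1-methylethyl on a saturated chain carbon bound to a nitrogen on an aromatic ring, or, cut one bond further out, ethyl in place of 2-hydroxy-2-methylpropyl. Within the data shown here, because compound 2 has no value, no step from compound 2 to compound 3 can be sized, and none beyond the scatter can be claimed in either direction. The expectation for compound 3 rests on compound 1 alone, whose cyclopropylmethyl group is likewise a small saturated chain on the same nitrogen, and because compound 1 gives 52.4 nM compound 3 is expected to give about 70 nM, with a range from 20 nM to 250 nM.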

Compound 3, half-maximal inhibitory concentration: 113 nM
Compound 3: middle estimate off by 1.6-fold (0.21 log units), on the low side; measured number inside the range.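

The nitrogen substituent of the shared core now has a measured effect: methyl in place of cyclopropyl on a saturated chain carbon bound to a nitrogen on an aromatic ring gives a 2.2-fold higher number from compound 1 to compound 3 (0.33 log units; beyond the scatter) and so shows that in this assay the number responds to this change, though only modestly, with the ethyl group of compound 3 still leaving a value of the same general order as the cyclopropylmethyl group of compound 1. Steps to or from compound 2 cannot be read, so the result says nothing about what the 2-hydroxy-2-methylpropyl group does at this position. Nothing available accounts for the difference between the ethyl and cyclopropylmethyl groups.

Still open, on these data alone, is whether a longer unbranched chain such as propyl or butyl on this nitrogen would give a number closer to that of compound 1 or to that of compound 3. Also open, as far as these compounds go, is how a chain ending in an amine or a carboxylic acid would read in this assay against these two small saturated chains.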